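Swapping the Aryl Group on a Fused Core

This account rests on a few compounds, and the source may have more. Where it says the series, first, only, none or still open, it means among the compounds named here.

Compound 3 `Cc1nc2c3ccccc3ccc2c2nc3c(ccc4ccccc43)c(-c3cc([N+](=O)[O-])ccc3N)c12` shows the highest number among the three measured compounds in a functional assay on AGS cells (Homo sapiens) for cytotoxicity, read by MTT assay, with a stated time of 48 h (a higher number here means a weaker inhibitor, a lower number a stronger inhibitor), giving 17800 nM. Compound 1 `Cc1nc2c3ccccc3ccc2c2nc3c(ccc4ccccc43)c(-c3cccnc3)c12` gives 3960 nM, and compound 2 `Cc1nc2c3ccccc3ccc2c2nc3c(ccc4ccccc43)c(-c3nccnc3N)c12` gives 2260 nM; the steps of a 4.5-fold higher number from compound 1 to compound 3 (0.65 log units; beyond the scatter) and a 7.9-fold higher number from compound 2 to compound 3 (0.90 log units; beyond the scatter) both point the same way. Compound 4 `Cc1nc2c3ccccc3ccc2c2nc3c(ccc4ccccc43)c(-c3ccc(O)cc3)c12` has not been measured; it differs from compound 3 in one place: 4-hydroxyphenyl in place of 2-amino-5-nitrophenyl on an aromatic carbon. Both measured steps bear on this change, since each exchanged the 2-amino-5-nitrophenyl group for another single aromatic ring and each moved the number by a modest amount beyond the scatter. A comparable lowering is therefore expected here, as a 4.5-fold lower number from compound 3 to compound 4 (0.65 log units; beyond the scatter). Compound 4 is expected to give about 4000 nM in this assay, within a range from 1500 nM to 11000 nM.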

Compound 4, half-maximal inhibitory concentration: 14200 nM
Beside the measured number, compound 4's estimate is 3.6-fold (0.55 log units) below it, outside the stated range (above it).
By their numbers in this assay, from the lowest: compounds 2 and 1 (each within the scatter of the next); then compounds 4 and 3 (each within the scatter of the next).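

In this assay, the change to 4-hydroxyphenyl gives a 1.3-fold lower number from compound 3 to compound 4 (0.10 log units; within the scatter), so replacing 2-amino-5-nitrophenyl does not by itself shift the number at this position. Within the data shown here, the two aryl rings of carbon only stay apart from the two rings that hold nitrogen, as a 6.3-fold higher number from compound 2 to compound 4 (0.80 log units; beyond the scatter) and a 3.6-fold higher number from compound 1 to compound 4 (0.55 log units; beyond the scatter) show, and no compound here goes against this split. Nothing available explains the split. As far as these compounds go, whether an unsubstituted phenyl ring or a pyridin-4-yl ring would fall with the carbon-only pair or the nitrogen-containing pair remains open. So does the effect of a carboxylic acid on the ring.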